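Swapping the Ethoxyphenyl Arm: An Expected Lipophilicity Reading

The compounds below may be only part of what the source reports. "The series", "measured", "known", "first", "only" and "open" are said of these compounds alone.

Among the measured compounds shown here, compound 1 `CCOc1ccccc1-c1ccc(-c2nc3cnccc3c(N[C@H](CC)C(N)=O)c2C#N)cc1` is the more lipophilic of the two compounds measured so far: in a physicochemical assay for lipophilicity, read by HPLC, at pH 7.5 (on this read-out higher numbers stand for higher lipophilicity and lower numbers for lower lipophilicity), compound 1 gives 3. Compound 2 `CCOc1ccccc1-c1ccc(-c2nc3cnccc3c(N[C@H](CC)C(=O)NS(=O)(=O)C3CC3)c2C#N)cc1` gives 2.3 in this assay; that step, a number 0.70 log units lower from compound 1 to compound 2 (beyond the scatter), came from a cyclopropylsulfonyl in place of hydrogen on an amide-type nitrogen. Compound 3 `CC[C@@H](Nc1c(C#N)c(-c2ccc(-c3cccc(C)c3F)cc2)nc2cnccc12)C(N)=O` differs from compound 1 at a different place altogether: 2-fluoro-3-methylphenyl in place of 2-ethoxyphenyl on an aromatic carbon. For the measured compounds named here, no measured step touches this aromatic carbon, so the one step in hand does not bear on the change, and the only guide is the change itself, as counted above. On that basis a small step upward in this assay is expected, a number 0.30 log units higher from compound 1 to compound 3 (within the scatter), which may well fall within the scatter of repeated readings. Compound 3 is therefore estimated at 3.3, with a range from 2.9 to 3.7.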

Compound 3, distribution coefficient: 3
Beside the measured number, compound 3's estimate is 0.30 log units above it; low and high end bracket the measured number.
By their numbers in this assay, from the lowest: compound 2; then compounds 1 and 3 (each within the scatter of the next).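

In this assay, the aromatic carbon para to a large group now has a measured change of its own: 2-fluoro-3-methylphenyl in place of 2-ethoxyphenyl gives no change at the digits printed from compound 1 to compound 3 (within the scatter). The earlier step concerned the amide-type nitrogen and said nothing about this carbon, whereas this exchange shows that a swap of one aryl group for another here, with the oxygen and its hydrogen-bond acceptor leaving and a fluorine and a methyl entering, leaves the read-out within the scatter. Nothing available offers an explanation for this outcome.

As far as these compounds go, whether other groups on this aromatic carbon would behave alike remains open, for instance a phenyl ring carrying an amine or a carboxylic acid. Also open, from the compounds shown here alone, is whether cyclopropylsulfonyl on the amide-type nitrogen would give a similar step alongside 2-fluoro-3-methylphenyl.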